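From 4-chlorophenyl to 3-bromophenyl on a shared core

The compounds below may be only part of what the source reports. "The series", "measured", "known", "first", "only" and "open" are said of these compounds alone.

Measured in a functional assay on U-251 cells (Homo sapiens) for antiproliferative activity, read by MTT assay, with a stated time of 24 h; on this read-out lower numbers stand for stronger inhibition and higher numbers for weaker inhibition:
compound 1 `COc1cc(OC)c(-c2coc3cc(OCC=C(C)C)ccc3c2=O)cc1OC`: 3500 nM
compound 2 `COc1cc(OC)c(-c2coc3cc(OCc4ccc(F)cc4)ccc3c2=O)cc1OC`: 3200 nM
compound 3 `COc1cc(OC)c(-c2coc3cc(OCc4ccc(Cl)cc4)ccc3c2=O)cc1OC`: 470 nM

Compound 3 has the lowest number of the three, and both other values lie clearly above it. The next compound, compound 4 `COc1cc(OC)c(-c2coc3cc(OCc4cccc(Br)c4)ccc3c2=O)cc1OC`, keeps the shared core and changes one group: 3-bromophenyl in place of 4-chlorophenyl on a saturated chain carbon bound to an oxygen on an aromatic ring. Here 3-bromophenyl takes the place of 4-chlorophenyl on a saturated chain carbon bound to an oxygen on an aromatic ring.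

Going by the values given here, three measured steps bear on this change. The step of a 6.8-fold lower number from compound 2 to compound 3 (0.83 log units; beyond the scatter) exchanged only fluoro for chloro, which shows that a small change on this ring can shift the number. The step of a 7.4-fold lower number from compound 1 to compound 3 (0.87 log units; beyond the scatter) is of similar size, whereas the step of a 1.1-fold lower number from compound 1 to compound 2 (0.04 log units; within the scatter) shows no real change. Among the compounds with values here, no measured compound carries bromo, and the only phenyl groups measured here are 4-fluorophenyl and 4-chlorophenyl, so the estimate is loose. With 4-chlorophenyl gone, some loss of the low number of compound 3 at 470 nM is expected, though less than the full gap seen with the other groups. The expected change in this assay is toward a higher number, a 2.1-fold higher number from compound 3 to compound 4 (0.33 log units; beyond the scatter). The estimate for compound 4 is 1000 nM, with an expected range from 300 nM to 3200 nM.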

Compound 4, half-maximal inhibitory concentration: > 10000 nM
Compound 4 gave a limit, no number; the forecaster's own chance of this, stated with the estimate: 3%; at least 10-fold (1.00 log units) between middle value and limit.
By their numbers in this assay, from the lowest: compound 3; then compounds 2 and 1 (each within the scatter of the next). At a limit, above all of these: compound 4.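

In this assay, going by these compounds alone, compound 4 is the only compound of the four that gives a limit rather than a number: the limit of > 10000 nM in this assay, at which 1 of the 4 values shown sits. Exchanging 4-chlorophenyl for 3-bromophenyl gives an at least 21-fold higher number from compound 3 to compound 4 (1.32 log units; beyond the scatter), the largest step shown, so a group swap on this saturated chain carbon can do far more than the modest shifts seen among the earlier compounds. Within the data shown here, compound 4 also stands apart from the two compounds with higher numbers, with an at least 3.1-fold higher number from compound 2 to compound 4 (0.49 log units; beyond the scatter) and an at least 2.8-fold higher number from compound 1 to compound 4 (0.45 log units; beyond the scatter), so a halogen-bearing phenyl group does not by itself bring a low number here, and compound 3 remains the only compound with a clearly lower value.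

The step to compound 4 changes the halogen from chloro to bromo and also changes the name of the ring from 4-substituted to 3-substituted, and the compounds shown cannot tell these two changes apart. A 4-bromophenyl or a 3-chlorophenyl group at this place would separate them, and the data give no explanation for the size of the step.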